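Swapping the amide tail of a dihydropyridine ester

The source may report more compounds than this note shows. Statements on the series, on what has been measured and on what is new or still open speak of the compounds shown alone.

Measured compounds:
compound 1 `CCOC(=O)C1=C(C)NC(C)=C(C(=O)OCC)C1c1ccc(OCC(=O)NCc2ccccc2)cc1`: 31.1%
compound 2 `CCOC(=O)C1=C(C)NC(C)=C(C(=O)OCC)C1c1ccc(OCC(=O)NNC(=O)c2ccsc2Cl)cc1`: 53.3%

In a functional assay on the whole organism (strain Wistar) for inhibition, with Rattus norvegicus as the target, read by paw edema, with stated times of 30 min and 3 h, at a dose of 20 mg/kg (a higher number here means more inhibition at the dose given (going by the name of the read-out), a lower number less inhibition), compound 2 gives the higher of the two numbers, and the gap to compound 1 is beyond the scatter. That step, a number 22.2 percentage points higher from compound 1 to compound 2 (beyond the scatter), changed the group on an amide-type nitrogen. Compound 3 `CCOC(=O)C1=C(C)NC(C)=C(C(=O)OCC)C1c1ccc(OCC(=O)n2nc(C)cc2C)cc1` differs from compound 2 at a different place: a group of 7 heavy atoms (5 carbon, 2 nitrogen; one five-membered aromatic ring with 2 hetero atoms) in place of a group of 10 heavy atoms (5 carbon, 2 nitrogen, 1 oxygen, 1 sulfur, 1 chlorine; one five-membered aromatic ring with 1 hetero atom), on a carbonyl carbon. For the measured compounds named here, no measured step covers this change, so the expectation rests on the two values alone. Compound 3 is expected to land between them, a downward step a number 13.3 percentage points lower from compound 2 to compound 3 (beyond the scatter), giving an estimate of 40% with a range from 25% to 58%.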

Compound 3, a percentage reported as inhibition, in the whole organism at one dose (the size of the read-out at that dose, not a potency): 48.5%
For compound 3 the middle estimate is 8.5 percentage points below the measured one, and the stated range covers the measured number.
By their numbers in this assay, from the lowest: compound 1; then compounds 3 and 2 (each within the scatter of the next).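

In this assay, the step of a number 4.8 percentage points lower from compound 2 to compound 3 (within the scatter) shows that the carbonyl carbon can carry 3,5-dimethyl-1H-pyrazol-1-yl, a group without hydrogen-bond donors, and stay level with the group in compound 2. The same group gives a number 17.4 percentage points higher from compound 1 to compound 3 (beyond the scatter) when set against benzylamino, so two quite different groups now stand clear of that one. Nothing available explains these numbers. From the compounds shown here alone, whether a plain pyrazol-1-yl without the two methyl groups would hold this level stays open. So does the outcome with a carboxylic acid or a simple amine on that carbonyl carbon.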